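Chloromethylbenzyl Purines: Amino for Chloro Step

The source may report more compounds than this note shows. Statements on the series, on what has been measured and on what is new or still open speak of the compounds shown alone.

Measured compounds:
compound 1 `Nc1nc(Cl)c2ncn(Cc3ccc(CCl)cc3)c2n1` gives 6610 nM
compound 2 `ClCc1cccc(Cn2cnc3c(Cl)nc(Cl)nc32)c1` gives 1580 nM
compound 3 `ClCc1ccc(Cn2cnc3c(Cl)nc(Cl)nc32)cc1` gives 5620 nM

All three were run in a functional assay on DU-145 cells (Homo sapiens) for cytotoxicity, read by sulforhodamine B assay, with a stated time of 48 h; a higher number here means a weaker inhibitor of growth, a lower number a stronger inhibitor of growth. Compound 2 has the lowest number of the three; the nearest of the others is compound 3, whose number is higher beyond the scatter, and compound 1 stands further away still. Compound 2 and compound 3 are built from the same atoms joined differently, and the difference between the two cores is not broken down here.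

One change is seen once among the measured compounds: from compound 3 to compound 1, (amino in place of chloro on an aromatic carbon). This step gave a 1.2-fold higher number from compound 3 to compound 1 (0.07 log units; within the scatter), so within the series the replacement left the number essentially where it was.

The unmeasured compound 4 `Nc1nc(Cl)c2ncn(Cc3cccc(CCl)c3)c2n1` stands to compound 2 as compound 1 stands to compound 3: amino in place of chloro on an aromatic carbon. The place of the change is described in the same words in both pairs, so it is taken as the same change on a different core.

In this assay the step from compound 2 to compound 4 is expected to be small, about a 1.2-fold higher number from compound 2 to compound 4 (0.08 log units; within the scatter), because the matching step a 1.2-fold higher number from compound 3 to compound 1 (0.07 log units; within the scatter) stayed within the scatter. The wider range allows that a single prior example may not carry over fully to the core of compound 2. Compound 4 is therefore estimated at 1900 nM, with a range expected from 900 nM to 4500 nM.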

Compound 4, concentration for 50% growth inhibition: 4260 nM
Compound 4: the middle estimate sits 2.2-fold (0.35 log units) below what was measured, and the stated range covers the measured number.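

In this assay, amino in place of chloro gives a 2.7-fold higher number from compound 2 to compound 4 (0.43 log units; beyond the scatter), a step beyond the scatter, while the same change on the core of compound 3 stayed within the scatter. Read singly, the two steps look different, but set side by side they cannot be told apart: the same change on two cores in this assay, a 1.2-fold higher number (0.07 log units; within the scatter) from compound 3 to compound 1 and a 2.7-fold higher number (0.43 log units; beyond the scatter) from compound 2 to compound 4, 2.3-fold (0.36 log units) apart, within the scatter of two such steps

These two pairs therefore give no ground for calling the change dependent on the core, yet they are too few to show that it carries over from one core to another with a fixed size, so the step on one core remains only a rough guide to the step on the other.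

Still open, going by these compounds, is whether any group other than amino or chloro at this carbon, such as a methoxy group, a methylamino group or plain hydrogen, would move the number in either core. Also open, on these data alone, is how far the number depends on the chloromethyl group shared by all four compounds, which a hydroxymethyl or plain methyl group in its place would begin to answer.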